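The compounds below may be only part of what the source reports. "The series", "measured", "known", "first", "only" and "open" are said of these compounds alone.

Compound 2 `Cc1ccc(S(=O)(=O)c2cc3cnc(Nc4cccc5cccnc45)nc3n(C)c2=O)cc1` stands with the highest number among three compounds measured in a functional assay on K562 cells (Homo sapiens) for inhibition, read by trypan blue exclusion, with a stated time of 72 h; a lower number here means a stronger inhibitor, a higher number a weaker inhibitor; in that assay compound 2 gives 10000 nM. Its nearest neighbour is compound 3 `Cn1c(=O)c(C(=O)Nc2ccc(F)cc2)cc2cnc(Nc3ccc4[nH]ccc4c3)nc21`, which in this assay gives 5000 nM, a gap within the scatter, and the furthest is compound 1 `Cn1c(=O)c(S(=O)(=O)c2ccc(Cl)cc2)cc2cnc(Nc3ccc4[nH]ccc4c3)nc21`, which in this assay gives 100 nM, a gap beyond the scatter. Going by the values given here, the one single-point step on record, a 50-fold higher number from compound 1 to compound 3 (1.70 log units; beyond the scatter), concerns the group on an aromatic carbon of the shared core and not the aryl amine, so it does not bear directly on the change considered here. Compound 4 `Cc1ccc(S(=O)(=O)c2cc3cnc(Nc4cnc5[nH]ccc5c4)nc3n(C)c2=O)cc1` differs from compound 2 at the aryl amine: a group of 9 heavy atoms (7 carbon, 2 nitrogen; one five-membered aromatic ring with 1 hetero atom, one six-membered aromatic ring with 1 hetero atom) in place of a group of 10 heavy atoms (9 carbon, 1 nitrogen; one six-membered aromatic ring of carbon only, one six-membered aromatic ring with 1 hetero atom), on a nitrogen on an aromatic ring. Among the compounds with values here, compound 1 and compound 2 differ in two places at once, so their values show only that a change including the aryl amine can move the number far. On that thin basis, a step towards a lower number beyond the scatter is expected from compound 2 to compound 4, a 10-fold lower number from compound 2 to compound 4 (1.00 log units; beyond the scatter), because compound 1 with a hydrogen-bond donor on the aryl amine gives 100 nM. Compound 4 is therefore estimated at 1000 nM in this assay, with a range from 150 nM to 6000 nM.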

Compound 4, half-maximal inhibitory concentration: 15000 nM
Beside the measured number, compound 4's estimate is 15-fold (1.18 log units) below it; measured number above the stated range.
By their numbers in this assay, from the lowest: compound 1; then compounds 3, 2 and 4 (each within the scatter of the next, the first and the last beyond it).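

At this position, on a nitrogen on an aromatic ring, replacing quinolin-8-yl with a group of one five-membered and one six-membered aromatic ring, which has 1 hydrogen-bond donor where quinolin-8-yl has 0, gives a 1.5-fold higher number from compound 2 to compound 4 (0.18 log units; within the scatter) in this assay, so this assay does not tell the two aryl amines apart. Going by these compounds alone, this pair is the first reading of the aryl amine on its own, and in it the added hydrogen-bond donor does not go with a lower number, a finding that holds only for these two compounds. Nothing available explains this result.

Compound 1 differs from both compound 2 and compound 4 in two places at once, so those steps cannot be read, and the value of compound 1, 100 nM, cannot be assigned to either the aryl amine or the group on the aromatic carbon. Also open, as far as these compounds go, is how the number would respond to a quite different group on this nitrogen, such as a phenyl ring carrying a piperazine or a carboxylic acid.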